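The source may report more compounds than this note shows. Statements on the series, on what has been measured and on what is new or still open speak of the compounds shown alone.

The shared core of compound 1 `Cc1cc(=O)n(-c2ccccc2C(F)(F)F)nc1C(=O)Nc1ccc(Oc2ncnc3ccsc23)cc1` carries a varied aryl group on an aromatic nitrogen. In a functional assay on A549 cells (Homo sapiens) for cytotoxicity, read by MTT assay, with a stated time of 72 h (on this read-out lower numbers stand for stronger inhibition and higher numbers for weaker inhibition), compound 1 gives 8850 nM. Compound 2 `Cc1cc(=O)n(-c2ccc(Br)cc2F)nc1C(=O)Nc1ccc(Oc2ncnc3ccsc23)cc1` gives 7930 nM. Compound 3 `Cc1cc(=O)n(-c2cccc(F)c2)nc1C(=O)Nc1ccc(Oc2ncnc3ccsc23)cc1` gives 9540 nM, the highest of the three numbers, though all three sit within the scatter of one another. Compound 4 `Cc1ccc(-n2nc(C(=O)Nc3ccc(Oc4ncnc5ccsc45)cc3)c(C)cc2=O)cc1` differs from compound 3 by 4-methylphenyl in place of 3-fluorophenyl on an aromatic nitrogen. The measured aryl swaps at this position bear directly on it: a 1.1-fold lower number from compound 1 to compound 2 (0.05 log units; within the scatter), a 1.1-fold higher number from compound 1 to compound 3 (0.03 log units; within the scatter) and a 1.2-fold higher number from compound 2 to compound 3 (0.08 log units; within the scatter), each within the scatter. No step beyond the scatter is therefore expected in this assay for this change either. The expected step is a 1.0-fold lower number from compound 3 to compound 4 (0.02 log units; within the scatter). Compound 4 is estimated at 9200 nM, with a range from 4500 nM to 19000 nM.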

Compound 4, half-maximal inhibitory concentration: 11500 nM
Compound 4: the middle estimate sits 1.3-fold (0.10 log units) below what was measured; the range from low to high includes it.
By their numbers in this assay, from the lowest: compounds 2, 1, 3 and 4 (each within the scatter of the next).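

In this assay, 4-methylphenyl on the aromatic nitrogen stays within the scatter of all three earlier aryl groups (a 1.2-fold higher number from compound 3 to compound 4 (0.08 log units; within the scatter), a 1.5-fold higher number from compound 2 to compound 4 (0.16 log units; within the scatter) and a 1.3-fold higher number from compound 1 to compound 4 (0.11 log units; within the scatter)). For the compounds shown here, a methyl-bearing aryl group thus joins the fluoro, bromo and trifluoromethyl examples, and no step among the four compounds lies beyond the scatter. No measurement at hand accounts for this flat picture. As far as these compounds go, whether an aryl group carrying an amine or a carboxylic acid, or a longer alkyl chain in place of the aryl group, would give a step beyond the scatter remains open.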